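Chloro to methyl on a shared core

The compounds below may be only part of what the source reports. "The series", "measured", "known", "first", "only" and "open" are said of these compounds alone.

- Compound 1 `CC#C[C@@H](Cc1nnn[nH]1)c1ccc(OCc2ccc3sc(C#N)c(-c4ccccc4C)c3c2)cc1`: 0.533 h
- Compound 2 `CC#C[C@@H](Cc1nnn[nH]1)c1ccc(OCc2ccc3sc(Cl)c(-c4ccccc4C)c3c2)cc1`: 1.08 h

In an ADME assay on microsomes from liver (Rattus norvegicus) for metabolic stability (on this read-out lower numbers stand for a shorter-lived compound and higher numbers for a longer-lived compound), compound 2 holds the higher of the two numbers, with compound 1 lower by the step below. Compound 3 `CC#C[C@@H](Cc1nnn[nH]1)c1ccc(OCc2ccc3sc(C)c(-c4ccccc4C)c3c2)cc1` carries methyl in place of chloro on an aromatic carbon, next to the ring sulfur: methyl in place of chloro on an aromatic carbon. Among the measured compounds shown here, one measured step touches this carbon: a 2.0-fold higher number from compound 1 to compound 2 (0.31 log units; beyond the scatter). That step was modest and involved cyano, not methyl, so it offers only a rough guide. A small drop, possibly none beyond the scatter, is expected. The estimated change is a 1.4-fold lower number from compound 2 to compound 3 (0.13 log units; within the scatter). Compound 3 is expected at 0.8 h, within a range of 0.35 h to 1.6 h.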

Compound 3, half-life: 0.483 h
Estimate against measurement, compound 3: 1.7-fold (0.22 log units) above, and the stated range covers the measured number.
By their numbers in this assay, from the lowest: compounds 3 and 1 (each within the scatter of the next); then compound 2.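

In this assay the swap to methyl gives a 2.2-fold lower number from compound 2 to compound 3 (0.35 log units; beyond the scatter) and so leaves chloro with the highest number of the three groups on this carbon, next to the ring sulfur. With a 1.1-fold lower number from compound 1 to compound 3 (0.04 log units; within the scatter) as the step, methyl and cyano cannot be told apart here. Nothing available explains why chloro stands apart from the other two.

From the compounds shown here alone, whether bromo, methoxy or an amine on this carbon would match chloro remains open. So does whether the same order of groups would hold on a different core.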